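Methyl for Nitro: Expecting the Cytotoxicity of Compound 4

This account rests on a few compounds, and the source may have more. Where it says the series, first, only, none or still open, it means among the compounds named here.

Compound 1, `CN(C)CCCNc1ccc(/N=N/c2ccc([N+](=O)[O-])cc2)cc1`: 60000 nM in an ADME assay on Vero cells (Chlorocebus sabaeus) for cytotoxicity, read by crystal violet staining; on this read-out higher numbers stand for lower toxicity in this test and lower numbers for higher toxicity in this test
Compound 2, `Cc1c(/N=N/c2ccccc2)ccc(NC[C@@H]2CCCN3CCCC[C@H]23)c1C`: 60000 nM
Compound 3, `CN(C)CCCN(/N=N/c1c(F)cccc1F)c1ccccc1`: 25000 nM

On these three numbers compound 1 stands level with compound 2 at the digits shown, and the two of them together give the highest readings of the set. Compound 3 gives a lower number, and its gap to compound 1 lies beyond the usual scatter of this kind of measurement.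

Compound 4, `Cc1ccc(/N=N/c2ccc(NCCCN(C)C)cc2)cc1`, is still to be measured in this assay. It differs from compound 1 in one place: methyl in place of nitro on an aromatic carbon. Within the data shown here, no pair among the measured compounds differs in a single place, so there is no directly comparable step to lean on. Given that compound 1 gives 60000 nM and the change touches only a small group on the aromatic ring, the step from compound 1 to compound 4 is expected to be a 1.2-fold lower number from compound 1 to compound 4 (0.08 log units; within the scatter), that is, no step beyond the scatter.

Compound 4 is therefore estimated to give 50000 nM in this assay, with a range from 20000 nM to 100000 nM.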

Compound 4, half-maximal cytotoxic concentration: 50000 nM
Compound 4: middle estimate and measured number agree at the digits printed; measured number inside the range.
By their numbers in this assay, from the lowest: compounds 3, 4, 1 and 2 (each within the scatter of the next, the first and the last beyond it).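

With compound 4 the set gains its first comparison of two compounds that differ in one place: in this assay, methyl in place of nitro gives a 1.2-fold lower number from compound 1 to compound 4 (0.08 log units; within the scatter). The change sits on an aromatic carbon, para to a large group, and nitro, with 3 heavy atoms and 2 hydrogen-bond acceptors, gives way to methyl, with 1 heavy atom and 0 hydrogen-bond acceptors, without a step beyond the scatter. Among these compounds, this holds for this one exchange on the core of compound 1 and says nothing yet about compounds 2 and 3, which remain linked to it by no single-place step.

From the compounds shown here alone, whether an amine, a carboxylic acid or a trifluoromethyl group at this position would also stay within the scatter remains open. Nothing shown here gives a measured reason for the result.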